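One methyl on the benzyl group of compound 2

The source may report more compounds than this note shows. Statements on the series, on what has been measured and on what is new or still open speak of the compounds shown alone.

For the measured compounds named here, in a functional assay on HCT-116 cells (Homo sapiens) for inhibition, read by MTT assay, with a stated time of 48 h (a higher number here means a weaker inhibitor, a lower number a stronger inhibitor), compound 2 `COc1ccc(-n2c(SCc3ccccc3)nnc2-c2cc(OC)c(OC)c(OC)c2)cc1` gives 42400 nM as the only true number so far. Compound 1 `COc1ccc(-n2c(SC)nnc2-c2cc(OC)c(OC)c(OC)c2)cc1` reads > 60000 nM and this is a limit of the assay, not a number. Going by the values given here, one measured step bears on the same side chain: an at least 1.4-fold lower number from compound 1 to compound 2 (0.15 log units; that floor lies within the scatter) came with phenyl in place of hydrogen on a saturated chain carbon bound to a sulfur. Compound 3 `COc1ccc(-n2c(SCc3ccc(C)cc3)nnc2-c2cc(OC)c(OC)c(OC)c2)cc1` takes the change methyl in place of hydrogen on an aromatic carbon on that group, methyl in place of hydrogen on an aromatic carbon, so benzyl becomes 4-methylbenzyl. The earlier step is known only as a floor and brought in a larger group, so it offers little guide here, and in this assay nothing beyond the scatter is expected. The estimate means a 1.1-fold lower number from compound 2 to compound 3 (0.05 log units; within the scatter) as the expected step. Compound 3 is expected at 38000 nM in a range from 18000 nM to 60000 nM for repeat measurements.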

Compound 3, half-maximal inhibitory concentration: 33300 nM
The estimate for compound 3 lay 1.1-fold (0.06 log units) above the measured number, within the range that was stated.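

Unlike the earlier step, this one rests on two true numbers: a 1.3-fold lower number from compound 2 to compound 3 (0.10 log units; within the scatter). In this assay, then, a methyl on the aromatic ring of the benzyl group, para to a large group, brings no change that can be told from the scatter. The step across the whole side chain reads an at least 1.8-fold lower number from compound 1 to compound 3 (0.25 log units; that floor lies within the scatter), but the value of compound 1 is a limit of the assay and not a number, so this floor does not give the true size of the step: the limit of > 60000 nM in this assay, at which 1 of the 3 values shown sits.

As far as these compounds go, whether any group at this place can move the number beyond the scatter remains open. A carboxylic acid or an amine in place of the methyl, or a longer chain between the sulfur and the ring, would put that question to the test.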